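The source may report more compounds than this note shows. Statements on the series, on what has been measured and on what is new or still open speak of the compounds shown alone.

Measured in an ADME assay on HUVEC cells (Homo sapiens) for cytotoxicity, read by MTT assay, with a stated time of 72 h; a lower number here means a stronger inhibitor, a higher number a weaker inhibitor:
- compound 1 `COc1ccc(-n2ccnc2-c2cc(OC)c(OC)c(OC)c2)cc1[N+](=O)[O-]`: "not determined" (no result reported)
- compound 2 `COc1cc(OC)cc(-n2ccnc2-c2cc(OC)c(OC)c(OC)c2)c1`: "not determined" (no result reported)
- compound 3 `COc1cc(-c2nccn2-c2cccc([N+](=O)[O-])c2)cc(OC)c1OC`: > 100000 nM (a limit, not a number)

Compound 1 offers no number as a starting point, since in this assay compound 1 stands at "not determined" (no result reported). Among the measured compounds shown here, the only reading anywhere near it is the limit of > 100000 nM in this assay, at which 1 of the 3 values shown sits. Compound 2 gives no help, because compound 2 also stands at "not determined" (no result reported).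

The next step leads from compound 1 to compound 4 `COc1ccc(-n2ccnc2-c2cc(OC)c(OC)c(OC)c2)cc1N`, which is still unmeasured in this assay. The change is amino in place of nitro on an aromatic carbon. In words, amino replaces nitro on an aromatic carbon, ortho to a methoxy group and meta to a large group, while the rest of the core of compound 1 stays as it is.

For the measured compounds named here, no measured step gives a size for this change, so the expectation rests on the structural change alone and remains loose. A step toward stronger inhibition, beyond the usual scatter, is expected, with compound 4 more likely to return a number than a limit. For compound 4 the expected half-maximal inhibitory concentration is 500 nM, with an estimated range of 15 nM to 30000 nM.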

Compound 4, half-maximal inhibitory concentration: 58500 nM
Compound 4: middle estimate off by 120-fold (2.07 log units), on the low side; the whole stated range lies below it.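

In this assay compound 4 gives 58500 nM, whereas compound 1 stands at "not determined" (no result reported), so no step can be read between compound 1 and compound 4. The compounds shown leave open how large the effect of amino in place of nitro on the shared core is in this assay.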